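Moving the Ring Nitrogen in a Piperazine Side Group

The compounds below may be only part of what the source reports. "The series", "measured", "known", "first", "only" and "open" are said of these compounds alone.

Compound 1 `Nc1ccccc1NC(=O)c1ccc(CSC(=S)N2CCN(Cc3ccccn3)CC2)cc1` gives 20.7% in a functional assay on A-375 cells (Homo sapiens) for antiproliferative activity, read by CCK-8 assay, with a stated time of 72 h, tested at 2 uM; on this read-out higher numbers stand for a stronger effect at the one concentration tested and lower numbers for a weaker effect.
Compound 2 `Cc1ccc(N2CCN(C(=S)SCc3ccc(C(=O)Nc4ccccc4N)cc3)CC2)cc1` gives 25.8% in this assay.
Compound 3 `CN1CCN(C(=S)SCc2ccc(C(=O)Nc3ccccc3N)cc2)CC1` gives 36.6% in this assay.

Among these three numbers compound 1 stands lowest. Its distance to compound 2 is a number 5.1 percentage points higher from compound 1 to compound 2 (within the scatter), which is within the scatter, while its distance to compound 3 is a number 15.9 percentage points higher from compound 1 to compound 3 (beyond the scatter), which is beyond it, as is a number 10.8 percentage points higher from compound 2 to compound 3 (beyond the scatter).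

Compound 4 `Nc1ccccc1NC(=O)c1ccc(CSC(=S)N2CCN(Cc3cccnc3)CC2)cc1` differs from compound 1 in one place: pyridin-3-yl in place of pyridin-2-yl on a saturated chain carbon bound to an amine nitrogen in a ring. The same atoms are present in both; only the point of attachment on the aromatic ring moves.

Going by the values given here, two measured steps touch the same part of the molecule. Removing the ring entirely gave a number 15.9 percentage points higher from compound 1 to compound 3 (beyond the scatter), and exchanging it for 4-methylphenyl gave a number 5.1 percentage points higher from compound 1 to compound 2 (within the scatter). Neither step keeps the ring and merely shifts its nitrogen, so the data give no direct guide for this change. Since swapping the group for a different aromatic ring moved the number only within the scatter, a step of about that size, upward or none at all, is expected here: a number 4.3 percentage points higher from compound 1 to compound 4 (within the scatter).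

Compound 4 is therefore estimated at 25%, with a range from 12% to 38%.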

Compound 4, a percentage reported as inhibition, at one concentration (the size of the read-out at that concentration, not a potency): 31.5%
The estimate for compound 4 lay 6.5 percentage points below the measured number; the measured number falls inside the stated range.
By their numbers in this assay, from the lowest: compounds 1, 2, 4 and 3 (each within the scatter of the next, the first and the last beyond it).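

In this assay the move from pyridin-2-yl to pyridin-3-yl gives a number 10.8 percentage points higher from compound 1 to compound 4 (beyond the scatter) and so shows that, on this saturated chain carbon, the point of attachment of the ring can register on its own, with the atoms and the counts of the group unchanged. The earlier steps shown here could not show this, as each of them replaced or removed the ring, and a pyridine ring here turns out not to be tied to a low number: the data give a number 5.1 percentage points lower from compound 3 to compound 4 (within the scatter) and also a number 5.7 percentage points higher from compound 2 to compound 4 (within the scatter) and place compound 4 within the scatter of both. No measurement on hand explains why the shift of attachment counts here.

Going by these compounds, with a single pair of pyridine isomers, it stays open how a pyridin-4-yl group or a plain phenyl ring on the same carbon would read, and so whether pyridin-2-yl pulls the number down or pyridin-3-yl lifts it. All of these numbers come from one cell line at one concentration, so they leave open how potency itself shifts with this change.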